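The compounds below may be only part of what the source reports. "The series", "measured", "known", "first", "only" and "open" are said of these compounds alone.

Of the compounds shown here, three on one shared core have been measured so far in an ADME assay on microsomes from liver (Mus musculus) for metabolic stability, read by LC-MS, with NADPH named in the record, with a stated time of 60 min, tested at 1 uM, in the absence of a further agent (on this read-out higher numbers stand for a more stable compound and lower numbers for a less stable compound), and all three give a limit. Compound 1 `COc1ccc(-c2c(C)nc3c(N4CC[C@@H](NS(=O)(=O)C5CC5)C4)cc(C)nn23)cc1OC` carries cyclopropyl on the sulfonyl sulfur and gives > 95% as a limit of the assay, not a number. Compound 2 `COc1ccc(-c2c(C)nc3c(N4CC[C@@H](NS(=O)(=O)c5ccccc5)C4)cc(C)nn23)cc1OC` carries phenyl there and gives > 95% as a limit too. Compound 3 `COc1ccc(-c2c(C)nc3c(N4CC[C@@H](NS(=O)(=O)c5ccc(C)cc5)C4)cc(C)nn23)cc1OC` carries 4-methylphenyl there and gives > 95% as a limit as well. Compound 3 therefore stands at the limit of > 95% in this assay, at which 3 of the 3 values shown sit, and has no exact number of its own.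

Compound 4 `COc1ccc(-c2c(C)nc3c(N4CC[C@@H](NS(=O)(=O)c5ccc(C(F)(F)F)cc5)C4)cc(C)nn23)cc1OC` has trifluoromethyl in place of methyl on an aromatic carbon, para to a large group (trifluoromethyl in place of methyl on an aromatic carbon). The nearest guide is a step that the two limits leave unreadable from compound 2 to compound 3 at that same aromatic carbon, while a step that the two limits leave unreadable from compound 1 to compound 2 and a step that the two limits leave unreadable from compound 1 to compound 3 are changes on the sulfonyl sulfur. No size can be read from any of them, yet none left the limit. In this assay the expected change is a step that the limit leaves unreadable from compound 3 to compound 4 and so no step beyond the usual scatter. For compound 4 the estimated value is 96% within a range from 85% to 100% and the result may again be only a limit.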

Compound 4, percent of the compound remaining: > 95%
Compound 4: no number, only a limit (the forecaster's own chance of this, stated with the estimate: 70%); the middle value is on the limit's open side.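

No size can be read for the steps to compound 4 from compound 1, compound 2 or compound 3, as all four compounds give a limit of the assay rather than a number: the limit of > 95% in this assay, at which 4 of the 4 values shown sit.

On these data alone, whether these four compounds differ at all in stability stays open.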